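Nitrophenyl to cyanophenyl on the triazole of a cinnamic acid

The source may report more compounds than this note shows. Statements on the series, on what has been measured and on what is new or still open speak of the compounds shown alone.

Measured compounds:
compound 1 `COc1ccccc1-n1cc(COc2c(/C=C\C(=O)O)ccc(OC)c2CC=C(C)C)nn1`: "not determined" (no result reported)
compound 2 `COc1ccc(/C=C\C(=O)O)c(OCc2cn(-c3cccc([N+](=O)[O-])c3)nn2)c1CC=C(C)C`: 15400 nM

Compound 1 `COc1ccccc1-n1cc(COc2c(/C=C\C(=O)O)ccc(OC)c2CC=C(C)C)nn1` carries a 2-methoxyphenyl on the triazole nitrogen, but in a functional assay on T47D cells (Homo sapiens) for cytotoxicity, read by MTT assay, with a stated time of 24 h (on this read-out higher numbers stand for weaker inhibition and lower numbers for stronger inhibition), compound 1 gives "not determined" (no result reported), so no result is reported for it. Among the compounds with values here, compound 2 `COc1ccc(/C=C\C(=O)O)c(OCc2cn(-c3cccc([N+](=O)[O-])c3)nn2)c1CC=C(C)C` is therefore the only compound with a number: in this assay compound 2 gives 15400 nM, a weak effect on these cells, and there is no second measured compound against which to set it, so no step between measured compounds can be given.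

Compound 3 `COc1ccc(/C=C\C(=O)O)c(OCc2cn(-c3ccccc3C#N)nn2)c1CC=C(C)C` is the compound still to be tested. It differs from compound 2 in one place: 2-cyanophenyl in place of 3-nitrophenyl on an aromatic nitrogen. The aryl group on the triazole nitrogen changes its substituent and the position of that substituent, while the core and the acid-bearing side of the molecule are unchanged.

Within the data shown here, with only one measured value and no step to guide the size of this change, compound 3 is expected to stay close to compound 2, with a step of a 1.0-fold lower number from compound 2 to compound 3 (0.01 log units; within the scatter) that is not expected to go beyond the usual scatter. Compound 3 is estimated at 15000 nM, with a range from 5000 nM to 50000 nM.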

Compound 3, half-maximal inhibitory concentration: 8800 nM
Beside the measured number, compound 3's estimate is 1.7-fold (0.23 log units) above it; measured number inside the range.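

In this assay, within the data shown here, putting 2-cyanophenyl in place of 3-nitrophenyl on the aromatic nitrogen gives a 1.8-fold lower number from compound 2 to compound 3 (0.24 log units; within the scatter) and so provides the first readable step at this position. The lone value of compound 2 could not show how this read-out responds to a change in the aryl group, but here a nitro group gives way to a nitrile, the substituent moves on the ring, and the two compounds still cannot be told apart. No measurement offered here accounts for this outcome, and no cause can be assigned to it.

Substituent and position change together in this single step, so the compounds shown leave open how much of the outcome belongs to each of them. Going by these compounds, it also remains open whether an amine or a carboxylic acid on this aryl ring, or a longer chain on the triazole nitrogen in its place, would carry the number beyond the scatter of this assay.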